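A few compounds are considered here, and "the series" means these few. Any claim that something is new, unique, unknown or untested is made for them only; others in the source may bear on it.

Measured compounds:
Compound 1, `CC(=O)Nc1ccc(S(=O)(=O)NNc2ccc(C)cc2)cc1`, 51 nM.
Compound 2, `COc1ccc(NNS(=O)(=O)c2ccc(NC(C)=O)cc2)cc1`, 254 nM.
Compound 3, `CC(=O)Nc1ccc(S(=O)(=O)NNc2ccc(C(F)(F)F)cc2)cc1`, 1610 nM.

Among these three, compound 1 gives the lowest number in an assay for inhibition of Indoleamine 2,3-dioxygenase 1 (Homo sapiens), read by spectrophotometry, with stated times of 1 h and 4 h (on this read-out higher numbers stand for weaker inhibition and lower numbers for stronger inhibition), and both of its neighbours sit beyond the scatter: a 5.0-fold higher number from compound 1 to compound 2 (0.70 log units; beyond the scatter) and a 32-fold higher number from compound 1 to compound 3 (1.50 log units; beyond the scatter). The two substituted analogues also differ from each other, as a 6.3-fold higher number from compound 2 to compound 3 (0.80 log units; beyond the scatter) shows.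

Compound 4, `CC(=O)Nc1ccc(S(=O)(=O)NNc2ccc(Br)cc2)cc1`, keeps the shared core of compound 1 and changes only one substituent: bromo in place of methyl on an aromatic carbon. Among the compounds with values here, no measured step exchanges methyl for bromo, so the change is read against the two steps that leave compound 1. Both replacements of the methyl at this position, by methoxy and by trifluoromethyl, raised the number, one modestly and one by a large margin. Bromo is a single-atom group, like the methyl it replaces, and it is counted with the same number of donors and acceptors, so the expectation for compound 4 is a step in the same direction but of modest size, a 2.5-fold higher number from compound 1 to compound 4 (0.41 log units; beyond the scatter). Compound 4 is therefore estimated at 130 nM in this assay, within a range from 45 nM to 400 nM.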

Compound 4, half-maximal inhibitory concentration: 130 nM
For compound 4 middle estimate and measured number coincide at the digits printed, within the range that was stated.
By their numbers in this assay, from the lowest: compound 1; then compounds 4 and 2 (each within the scatter of the next); then compound 3.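

In this assay, bromo becomes the third replacement of the methyl on this aromatic carbon to raise the number (with a 2.5-fold higher number from compound 1 to compound 4 (0.41 log units; beyond the scatter)), so none of the replacements shown matches the methyl at this place. Within the data shown here, the result also divides those replacements, which the earlier compounds could not do: bromo cannot be told apart from methoxy (with a 2.0-fold lower number from compound 2 to compound 4 (0.29 log units; within the scatter)), while trifluoromethyl stands clear of bromo (with a 12-fold lower number from compound 3 to compound 4 (1.09 log units; beyond the scatter)), so the large rise seen with trifluoromethyl is not shared by every group tried here. Nothing available on these compounds accounts for this order among the four groups.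

The compounds shown leave open whether any other single group at this place, such as chloro, fluoro, a hydroxyl or an amine, would equal or improve on the methyl of compound 1. They also leave open how an ethyl or a longer chain would fare in place of the methyl, and whether the same order of groups would hold if the shared core were changed elsewhere.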